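A few compounds are considered here, and "the series" means these few. Any claim that something is new, unique, unknown or untested is made for them only; others in the source may bear on it.

Working notes on the series, read in a toxicity assay on HUVEC cells (Homo sapiens) for inhibition; a higher number here means a weaker inhibitor of growth, a lower number a stronger inhibitor of growth. Compound 1 (`Cc1nc(-c2ccccc2)c(C(=O)N2CCN(c3cccc(Cl)c3)CC2)o1`) gives 0.463 ug/mL and compound 2 (`Cc1cc(C)cc(N2CCN(C(=O)c3oc(C)nc3-c3ccccc3)CC2)c1`) gives 0.356 ug/mL. Within the data shown here, compound 2 therefore stands level with compound 1, its only measured neighbour, and the two cannot be separated on these numbers.

The next compound is compound 3 (`Cc1nc(-c2ccccc2)c(C(=O)N2CCN(c3cc(Cl)cc(Cl)c3)CC2)o1`), which has 3,5-dichlorophenyl in place of 3,5-dimethylphenyl on an amine nitrogen in a ring.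

Among the measured compounds shown here, one measured step bears on this change. It concerns the same place on the shared core: a 1.3-fold lower number from compound 1 to compound 2 (0.11 log units; within the scatter), with 3,5-dimethylphenyl in place of 3-chlorophenyl. That exchange of a chlorine-bearing ring for a dimethyl-bearing one left this assay within the scatter. For the measured compounds named here, the data hold no compound with a second chlorine on this ring, so this single step is thin support.

No change beyond the scatter is expected in either direction, and the expected step is a 1.2-fold higher number from compound 2 to compound 3 (0.07 log units; within the scatter).

For compound 3 the estimated value is 0.42 ug/mL, with an expected range of 0.2 ug/mL to 0.9 ug/mL.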

Compound 3, concentration for 50% growth inhibition: 0.191 ug/mL
Compound 3: the middle estimate sits 2.2-fold (0.34 log units) above what was measured; measured number outside the range, below it.
By their numbers in this assay, from the lowest: compounds 3, 2 and 1 (each within the scatter of the next, the first and the last beyond it).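

In this assay, among these compounds, a second chlorine on the aryl group carried by the ring amine nitrogen gives the first step that clears the scatter: a 2.4-fold lower number from compound 1 to compound 3 (0.38 log units; beyond the scatter). The exchange of 3,5-dimethylphenyl for 3,5-dichlorophenyl does not clear it, at a 1.9-fold lower number from compound 2 to compound 3 (0.27 log units; within the scatter), so compound 2 and compound 3 cannot be separated, just as compound 1 and compound 2 could not. This position therefore shows a measurable difference only between the two ends of the three-compound series, 3-chlorophenyl in compound 1 and 3,5-dichlorophenyl in compound 3, and nothing at hand gives a reason for that difference.

These three compounds leave open whether the step from compound 1 to compound 3 is specific to chlorine or would also appear with fluorine, bromine or trifluoromethyl on the same phenyl ring. They also leave open whether a phenyl ring with a methoxy group or a carboxylic acid, or a pyridine ring in its place, would stay level with compound 2 and compound 3 or fall outside the narrow span seen so far.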